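The source may hold more compounds than are shown below. What is called first, only, known or untested is meant among the compounds shown, and "the series" means these compounds.

Compound 1 `CC(=O)c1ccc(Nc2ccnc(SCC(=O)c3ccc(Br)cc3)n2)cc1` was tested in a functional assay on A498 cells (Homo sapiens) for inhibition, read by sulforhodamine B assay, with a stated time of 48 h, tested at 10 uM (a lower number here means less inhibition of growth, a higher number more inhibition of growth at the concentration tested), and gives 19%. Among the two measured compounds it stands lowest. The other measured compound, compound 2 `CCOC(=O)c1ccc(Nc2ccnc(SCC(=O)c3ccc(C#N)cc3)n2)cc1`, gives 50% in this assay, a higher number, and the gap lies beyond the usual scatter. Going by the values given here, compound 2 differs from compound 1 in more than one place, and the two values show only that compound 2 inhibits growth more at this concentration, not which change is behind that.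

Compound 3 `CC(=O)c1ccc(Nc2ccnc(SCC(=O)c3ccc(-c4ccccc4)cc3)n2)cc1` has not been measured yet. It differs from compound 1 in one place: phenyl in place of bromo on an aromatic carbon. Among the compounds with values here, no pair of measured compounds shows what such an exchange does, and there is nothing to measure the step against. A step that stays within or only slightly beyond the usual scatter, with no clear direction and at most a mild lean upward, is what seems reasonable to expect. In this assay compound 3 is therefore expected to give about 25%, somewhere between 5% and 50%. The step this implies, a number 6 percentage points higher from compound 1 to compound 3 (within the scatter), is an estimate rather than a measurement.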

Compound 3, percent growth inhibition at one concentration: 55%
Compound 3: the middle estimate sits 30 percentage points below what was measured; measured number outside the range, above it.
By their numbers in this assay, from the lowest: compound 1; then compounds 2 and 3 (each within the scatter of the next).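

Exchanging the bromo for a phenyl on this aromatic carbon, para to a large group, gives a number 36 percentage points higher from compound 1 to compound 3 (beyond the scatter) in this assay, so this is a place on the molecule where a single change can clearly alter growth inhibition at the concentration tested. The exchange replaces a single bromine atom with a six-membered aromatic ring of six carbon atoms, and the number goes up rather than down, so at least this much larger group is accepted at this position in the series shown. What lies behind the rise cannot be said from these numbers, as nothing at hand bears on its cause.

A single exchange cannot separate what the loss of the bromo contributes from what the arrival of the phenyl contributes, so the size of the step cannot yet be assigned to either group. On these data alone, it also remains open whether an amine, a carboxylic acid or a longer carbon chain at this same position would give a number closer to that of compound 1 or closer to that of compound 3.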